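Solubility Along a Quinolinone Series: Compound 2 to Compound 3

This account rests on a few compounds, and the source may have more. Where it says the series, first, only, none or still open, it means among the compounds named here.

Measured compounds:
Compound 1 `Oc1ccc(Cl)cc1-c1c(S)c(O)nc2ccc(C(F)(F)F)cc12`, 30 ug/mL
Compound 2 `OCCSc1c(O)nc2ccc(C(F)(F)F)cc2c1-c1cc(Cl)ccc1O`, 4 ug/mL

Among the compounds with values here, in a physicochemical assay for solubility (a higher number here means a more soluble compound, a lower number a less soluble compound), compound 2 gives the lowest of the two numbers so far; the nearest is compound 1, which reached 30 ug/mL. Within the data shown here, the only measured step is a 7.5-fold lower number from compound 1 to compound 2 (0.88 log units; beyond the scatter). Compound 3 `OCC(O)CSc1c(O)nc2ccc(C(F)(F)F)cc2c1-c1cc(Cl)ccc1O` is not yet measured. Its structure differs from compound 2 in one place: hydroxymethyl in place of hydrogen on a saturated chain carbon bound to an oxygen on a saturated carbon and a saturated chain carbon. Among the measured compounds shown here, no measured step bears directly on this kind of change, since the one known step concerns a group entering on a sulfur, not a hydroxymethyl entering on a saturated chain carbon. The account therefore leans on compound 2 alone, with 4 ug/mL as the anchor. The expected step is a 1.5-fold higher number from compound 2 to compound 3 (0.18 log units; within the scatter), a small rise or no change beyond the scatter. Compound 3 is thus estimated at 6 ug/mL, with a range from 2 ug/mL to 18 ug/mL.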

Compound 3, solubility: 190 ug/mL
Compound 3: the middle estimate sits 32-fold (1.50 log units) below what was measured, outside the stated range (above it).
By their numbers in this assay, from the lowest: compound 2; then compound 1; then compound 3.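

In this assay, the group on the sulfur does not push the number in a single direction: 2-hydroxyethyl gives a 7.5-fold lower number from compound 1 to compound 2 (0.88 log units; beyond the scatter), whereas 2,3-dihydroxypropyl gives a 6.3-fold higher number from compound 1 to compound 3 (0.80 log units; beyond the scatter). A single hydroxymethyl on the saturated chain carbon therefore reverses the direction of the change, with a 48-fold higher number from compound 2 to compound 3 (1.68 log units; beyond the scatter), the largest step among these compounds. No available evidence bears on why this small change has so large an effect.

As far as these compounds go, what stays open is whether the rise holds for a longer chain on the sulfur, such as 3,4-dihydroxybutyl, or for a chain ending in an amine or a carboxylic acid. The compounds shown also leave open whether the hydroxymethyl must sit on this chain carbon, since they include no other placement of it.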